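The source may report more compounds than this note shows. Statements on the series, on what has been measured and on what is new or still open speak of the compounds shown alone.

Measured so far in a functional assay on MCF7 cells (Homo sapiens) for inhibition, read by MTT assay, with a stated time of 72 h; on this read-out lower numbers stand for stronger inhibition and higher numbers for weaker inhibition:

Compound 1, `CN(C(=O)NC(=O)c1ccc(F)c(F)c1)c1nc(C(F)(F)F)c(C(=O)N/N=C/c2ccc(C(F)(F)F)cc2)s1`: 5.93 ug/mL
Compound 2, `CN(C(=O)NC(=O)c1ccc(F)c(F)c1)c1nc(C(F)(F)F)c(C(=O)N/N=C/c2cccc(C(F)(F)F)c2)s1`: 4.15 ug/mL

Among the compounds with values here, compound 2 gives the lowest of these two numbers, but the only measured step, a 1.4-fold lower number from compound 1 to compound 2 (0.16 log units; within the scatter), is within the scatter, so the two compounds cannot be told apart on this read-out.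

Compound 3, `CN(C(=O)NC(=O)c1ccc(F)c(F)c1)c1nc(C(F)(F)F)c(C(=O)N/N=C/c2ccc([N+](=O)[O-])cc2)s1`, is not yet measured. It differs from compound 2 in one place: 4-nitrophenyl in place of 3-(trifluoromethyl)phenyl on a carbon with a double bond to nitrogen. Within the data shown here, no measured step bears on this change. Among the measured compounds shown here, the single step known, a 1.4-fold lower number from compound 1 to compound 2 (0.16 log units; within the scatter), only moves a trifluoromethyl group to another position on the same ring and stays within the scatter; nothing shows what replacing that group by a nitro-bearing ring does. There is therefore no basis for expecting a shift in this assay beyond the scatter in either direction, only wider uncertainty. The expected step to compound 3 is a 1.2-fold higher number from compound 2 to compound 3 (0.08 log units; within the scatter). Compound 3 is estimated at 5 ug/mL, within a range from 2 ug/mL to 13 ug/mL.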

Compound 3, half-maximal inhibitory concentration: 4.81 ug/mL
Compound 3: the middle estimate sits 1.0-fold (0.02 log units) above what was measured, within the range that was stated.
By their numbers in this assay, from the lowest: compounds 2, 3 and 1 (each within the scatter of the next).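

The earlier pair only moved a trifluoromethyl group around one ring, whereas here the group itself is exchanged. In this assay, replacing 3-(trifluoromethyl)phenyl with 4-nitrophenyl gives a 1.2-fold higher number from compound 2 to compound 3 (0.06 log units; within the scatter), and the simpler swap of nitro for trifluoromethyl on an aromatic carbon gives a 1.2-fold lower number from compound 1 to compound 3 (0.09 log units; within the scatter), so this read-out separates neither the two groups nor the three compounds. Nothing available offers a reason why these compounds read alike.

Still open is whether this place can shift the read-out at all, since all three rings shown carry a single nitro or trifluoromethyl group. An unsubstituted phenyl ring, or a phenyl ring bearing an amine or a carboxylic acid, would test whether the result holds for other groups.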